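The source may hold more compounds than are shown below. What is called first, only, known or untested is meant among the compounds shown, and "the series" means these compounds.

Going by the values given here, compound 2 `CC(C)COC(=O)NS(=O)(=O)c1sc(CC(C)C)cc1-c1cccc(Cn2ccnc2)c1` is the stronger of the two compounds measured so far. In an assay on HEK293 cells for displacement of a labelled ligand from Type-2 angiotensin II receptor (Homo sapiens), read by scintillation counting, with a stated time of 240 min (on this read-out lower numbers stand for stronger inhibition and higher numbers for weaker inhibition), compound 2 gives 130 nM, the lowest of the two numbers recorded. Among the compounds with values here, its nearest neighbour, compound 1 `CCOC(=O)NS(=O)(=O)c1sc(CC(C)C)cc1-c1cccc(Cn2ccnc2)c1`, gives 300 nM in this assay, and the single measured step between them, a 2.3-fold lower number from compound 1 to compound 2 (0.36 log units; beyond the scatter), lies beyond the usual scatter.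

Compound 3 `CC(C)Cc1cc(-c2cccc(Cn3ccnc3)c2)c(S(=O)(=O)NC(=O)OC(C)(C)C)s1` has not yet been measured. It differs from compound 2 by tert-butyl in place of isobutyl on an oxygen next to a carbonyl group, so the two share the same atoms joined differently. Within the data shown here, the only measured step that bears on this change is a 2.3-fold lower number from compound 1 to compound 2 (0.36 log units; beyond the scatter), which also altered the group on the oxygen next to the carbonyl and gave a modest lowering of the number. Among the measured compounds shown here, no measured step, however, compares isobutyl with tert-butyl at that position, so the direction of the new step is uncertain. On this basis the expectation for compound 3 is a step of no change at the digits printed from compound 2 to compound 3 (within the scatter), within the scatter. The number for compound 3 in this assay is therefore estimated at 130 nM, with a likely range from 50 nM to 350 nM.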

Compound 3, inhibition constant: 270 nM
The estimate for compound 3 lay 2.1-fold (0.32 log units) below the measured number; the range from low to high includes it.
By their numbers in this assay, from the lowest: compound 2; then compounds 3 and 1 (each within the scatter of the next).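

In this assay the group on the oxygen next to a carbonyl group counts by how its carbons are joined and not only by how many there are: exchanging isobutyl for tert-butyl keeps the carbon count and still gives a 2.1-fold higher number from compound 2 to compound 3 (0.32 log units; beyond the scatter) in this small series. The lower number seen with isobutyl in place of ethyl therefore does not extend to every larger group at this place, for tert-butyl in place of ethyl gives a 1.1-fold lower number from compound 1 to compound 3 (0.05 log units; within the scatter) and so separates compound 1 and compound 3 by no more than the scatter. Nothing shown here accounts for why these two arrangements of the same carbons differ.

The compounds shown leave open how a longer chain such as n-hexyl, or a benzyl group, would read on this oxygen, and so whether isobutyl is a favourable choice or merely the best of three. They also leave open whether the same order among these groups would hold with a different group in place of the imidazole or the isobutyl on the shared core.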